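A few compounds are considered here, and "the series" means these few. Any claim that something is new, unique, unknown or untested is made for them only; others in the source may bear on it.

Going by the values given here, compound 2 `COCCC(=N)NCCC[C@H](N)C(=O)O` stands lowest of the three numbers so far in an assay on cells for inhibition of N(G),N(G)-dimethylarginine dimethylaminohydrolase 1 (Homo sapiens), with a stated time of 30 min (on this read-out higher numbers stand for weaker inhibition and lower numbers for stronger inhibition), and gives 9000 nM there. Compound 1 `COCC(=N)NCCC[C@H](N)C(=O)O` gives 73000 nM in this assay, while compound 3 `COCCC(=N)NCCCCN` gives 1450000 nM in this assay. Compound 4 `COCCCC(=N)NCCC[C@H](N)C(=O)O` has not yet been measured; it differs from compound 2 by methoxymethyl in place of methoxy on a saturated chain carbon, two bonds along the chain from a carbon with a double bond to nitrogen in the shared core. Of the measured steps, an 8.1-fold lower number from compound 1 to compound 2 (0.91 log units; beyond the scatter) bears most directly on this, being the same kind of chain extension read one bond further out, whereas a 160-fold higher number from compound 2 to compound 3 (2.21 log units; beyond the scatter) concerns a different part of the structure. A further lowering, smaller than that earlier step, is therefore expected. Compound 4 is estimated at 6000 nM in this assay, between 1500 nM and 25000 nM as its range, which amounts to an expected 1.5-fold lower number from compound 2 to compound 4 (0.18 log units; within the scatter) overall.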

Compound 4, inhibition constant: 156000 nM
Compound 4: middle estimate off by 26-fold (1.41 log units), on the low side; the whole stated range lies below it.
By their numbers in this assay, from the lowest: compound 2; then compound 1; then compound 4; then compound 3.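

In this assay, lengthening the chain at this position does not keep lowering the number: one step gives an 8.1-fold lower number from compound 1 to compound 2 (0.91 log units; beyond the scatter), but the next gives a 17-fold higher number from compound 2 to compound 4 (1.24 log units; beyond the scatter). The 3-methoxypropyl chain also falls short of the shorter methoxymethyl chain, with a 2.1-fold higher number from compound 1 to compound 4 (0.33 log units; beyond the scatter), so among these three the 2-methoxyethyl chain of compound 2 gives the lowest number. Nothing measured here accounts for this reversal. On these data alone, it remains open whether a longer chain would raise the number further, and whether a hydroxy group or an amine in place of the methoxy would show the same dependence on chain length.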